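This account rests on a few compounds, and the source may have more. Where it says the series, first, only, none or still open, it means among the compounds named here.

Series read in a functional assay on A-375 cells (Homo sapiens) for inhibition, read by CCK-8 assay, with a stated time of 72 h, tested at 2 uM; on this read-out lower numbers stand for less inhibition of growth and higher numbers for more inhibition of growth at the one concentration tested:
compound 1 `Nc1ccccc1NC(=O)c1ccc(CSc2ccc(Br)cc2)cc1` gives 4.35%
compound 2 `Nc1ccccc1NC(=O)/C=C/c1ccc(CSc2cccc(F)c2)cc1` gives 6.75%
compound 3 `Nc1ccccc1NC(=O)/C=C/c1ccc(CSCCc2ccccc2)cc1` gives 41.9%

Compound 1 holds the lowest of the three numbers in this assay. Compound 2 sits within the scatter of compound 1, so no order between those two can be read; compound 3 lies beyond the scatter above both.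

Compound 4 `Nc1ccccc1NC(=O)c1ccc(CSCCc2ccccc2)cc1` has not been measured. Against compound 1 it differs by phenethyl in place of 4-bromophenyl on a sulfur. Among the compounds with values here, one measured step bears on this change: a number 35.2 percentage points higher from compound 2 to compound 3 (beyond the scatter). That step exchanges an aryl group on the same sulfur for phenethyl and was large, but it was measured on the core of compound 2 and compound 3, not on the core of compound 1; whether the size carries over is not known from these three compounds. The group leaving here, 4-bromophenyl, is also not the group that left in the measured step.

For compound 4 a step upward in this assay beyond the scatter is therefore expected, of roughly the size seen from compound 2 to compound 3 and perhaps somewhat smaller, giving a number 30.7 percentage points higher from compound 1 to compound 4 (beyond the scatter). Compound 4 is estimated to reach 35%, with a range from 15% to 55%.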

Compound 4, percent growth inhibition at one concentration: 21.8%
The estimate for compound 4 lay 13.2 percentage points above the measured number; the measured number falls inside the stated range.
By their numbers in this assay, from the lowest: compounds 1 and 2 (each within the scatter of the next); then compound 4; then compound 3.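

In this assay, within the data shown here, the exchange of an aryl group on the sulfur for phenethyl gives a number 17.5 percentage points higher from compound 1 to compound 4 (beyond the scatter) and so shows on the core of compound 1 what had been seen only on the core of compound 2 and compound 3. The direction therefore holds on both cores shown, alongside a number 35.2 percentage points higher from compound 2 to compound 3 (beyond the scatter), with no compound going against it, although the step on the core of compound 1 is the smaller of the two and the group that leaves is 4-bromophenyl in one step and 3-fluorophenyl in the other. Nothing measured here explains the rise with phenethyl or the different sizes of the two steps.

The compounds shown leave open how much of that difference in size belongs to the core and how much to the aryl group that leaves. Also open, on these data alone, is how the number would respond on the same sulfur to a longer chain such as 3-phenylpropyl, or to a chain ending in an amine in place of the phenyl ring.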